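From ethyl to 4-hydroxyphenyl on compound 1

The source may hold more compounds than are shown below. What is called first, only, known or untested is meant among the compounds shown, and "the series" means these compounds.

Measured in a functional assay on MGC-803 cells (Homo sapiens) for cytotoxicity, read by MTT assay, with a stated time of 72 h; on this read-out higher numbers stand for weaker inhibition and lower numbers for stronger inhibition
compound 1 `CCC(C)=C1C(=O)N(c2ccc(Cl)cc2)N(c2ccc(Cl)cc2)C1=O` at 66500 nM
compound 2 `O=C1C(=Cc2ccc(F)cc2)C(=O)N(c2ccc(Cl)cc2)N1c1ccc(Cl)cc1` at 26000 nM
compound 3 `O=C1C(=Cc2ccc(Br)cc2)C(=O)N(c2ccc(Cl)cc2)N1c1ccc(Cl)cc1` at 16900 nM

Compound 1 holds the highest number of the three in this assay and its gaps to compound 2 and to compound 3 both lie beyond the scatter. The change 4-hydroxyphenyl in place of ethyl on a double-bonded chain carbon bound to a double-bonded ring carbon and a saturated chain carbon leads from compound 1 to compound 4 `CC(=C1C(=O)N(c2ccc(Cl)cc2)N(c2ccc(Cl)cc2)C1=O)c1ccc(O)cc1` and sits on a double-bonded chain carbon bound to a double-bonded ring carbon and a saturated chain carbon. Within the data shown here, the one measured step between neighbours is a 1.5-fold lower number from compound 2 to compound 3 (0.19 log units; within the scatter) and stays within the scatter, so it says little about this change. More relevant are compound 2 at 26000 nM and compound 3 at 16900 nM since both carry an aromatic ring on the matching chain carbon and both give lower numbers than compound 1 does. Among the measured compounds shown here, no measured compound carries 4-hydroxyphenyl, so this is only a loose guide. A moderate move toward a lower number is therefore expected in this assay and the expected size is a 2.7-fold lower number from compound 1 to compound 4 (0.42 log units; beyond the scatter) as an estimate. The estimate for compound 4 is 25000 nM and the expected range runs from 9000 nM to 70000 nM as the likely span.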

Compound 4, half-maximal inhibitory concentration: 42800 nM
Compound 4: the middle estimate sits 1.7-fold (0.23 log units) below what was measured, within the range that was stated.
By their numbers in this assay, from the lowest: compounds 3, 2, 4 and 1 (each within the scatter of the next, the first and the last beyond it).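

In this assay, the step at this position reads a 1.6-fold lower number from compound 1 to compound 4 (0.19 log units; within the scatter), so replacing ethyl with 4-hydroxyphenyl on a double-bonded chain carbon bound to a double-bonded ring carbon and a saturated chain carbon gives no change beyond the scatter. This is the first single-place change shown at this position, as the only earlier step concerned the halogen on an aromatic carbon. It shows that this position accepts an aromatic ring carrying a hydroxyl group in place of ethyl without a clear shift in this read-out, and nothing given here explains that outcome.

The compounds shown leave open whether an unsubstituted phenyl, an amine, a carboxylic acid or a longer chain at this position would give a step beyond the scatter. They also do not separate any contribution of the hydroxyl group from that of the ring.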